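Chloro for amino on a shared purine-like core, cytotoxicity expected

A few compounds are considered here, and "the series" means these few. Any claim that something is new, unique, unknown or untested is made for them only; others in the source may bear on it.

Compound 1 `Nc1nc(Cl)c2ncn(Cc3ccccc3CCl)c2n1` was tested in a functional assay on HOP-92 cells (Homo sapiens) for cytotoxicity, read by sulforhodamine B assay, with a stated time of 48 h (on this read-out higher numbers stand for weaker inhibition of growth and lower numbers for stronger inhibition of growth), and gives 30900 nM, the highest of the two numbers recorded. Its nearest neighbour is compound 3 `ClCc1ccccc1Cn1cnc2ncnc(Cl)c21`, which in this assay gives 12900 nM, a gap beyond the usual scatter. Compound 2 `ClCc1ccc(Cn2cnc3c(Cl)nc(Cl)nc32)cc1` in this assay gives "not determined" (no result reported), so no number is available for it. Compound 4 `ClCc1ccccc1Cn1cnc2c(Cl)nc(Cl)nc21` is not yet measured; it differs from compound 1 by chloro in place of amino on an aromatic carbon. Among the measured compounds shown here, no measured pair shows this change, so the direction is uncertain; a modest shift toward stronger growth inhibition is expected, since compound 3, also without the amino group, gives 12900 nM. Compound 4 is expected to give 15000 nM, within 5000 nM to 45000 nM, the step of a 2.1-fold lower number from compound 1 to compound 4 (0.31 log units; beyond the scatter) being an estimate only.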

Compound 4, concentration for total growth inhibition: 970 nM
Compound 4: middle estimate off by 15-fold (1.19 log units), on the high side, and the stated range ends above it.
By their numbers in this assay, from the lowest: compound 4; then compound 3; then compound 1.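

In this assay the position between two ring nitrogen atoms proves highly sensitive to this change: chloro in place of amino gives a 32-fold lower number from compound 1 to compound 4 (1.50 log units; beyond the scatter) and so a large move toward stronger inhibition of growth. The earlier compounds shown here offered no pair differing in one place, so they could not show how much this position matters. Nothing at hand explains the size of the step. Going by these compounds, whether a methoxy group or a methylamino group at this position would give similarly strong inhibition remains open, as does whether the step holds in other cell lines.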